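Sulfonyl substituent change from compound 3 to compound 4

The compounds below may be only part of what the source reports. "The series", "measured", "known", "first", "only" and "open" are said of these compounds alone.

In an ADME assay on microsomes (Homo sapiens) for metabolic stability (on this read-out higher numbers stand for fast clearance and lower numbers for slow clearance), compound 3 (`Cc1cc(C(F)(F)F)c2cccc(OCc3c(Cl)ccc(S(=O)(=O)N4CCC[C@H]4CO)c3Cl)c2n1`) gives 250 mL/min/kg. Compound 2 (`CCc1cc(C(F)(F)F)c2cccc(OCc3c(Cl)ccc(S(=O)(=O)N4CCC[C@H]4C(=O)NC)c3Cl)c2n1`) gives 300 mL/min/kg, within the scatter of compound 3. Compound 1 (`CNC(=O)[C@@H]1CCCN1S(=O)(=O)c1ccc(Cl)c(COc2cccc3c(-n4ccnc4)cc(C)nc23)c1Cl`) gives 33.3 mL/min/kg, lower than compound 3 by more than the scatter.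

Compound 4 (`Cc1cc(C(F)(F)F)c2cccc(OCc3c(Cl)ccc(S(=O)(=O)N4C[C@@H](C)O[C@@H](C)C4)c3Cl)c2n1`) carries 2,6-dimethylmorpholin-4-yl in place of 2-(hydroxymethyl)pyrrolidin-1-yl on a sulfonyl sulfur. Within the data shown here, no measured pair isolates this replacement, so the expectation is tentative. The expected change is a 1.3-fold lower number from compound 3 to compound 4 (0.10 log units; within the scatter), slightly downward and not beyond the scatter in this assay. Compound 4 is estimated at 200 mL/min/kg, with an expected range of 90 mL/min/kg to 350 mL/min/kg.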

Compound 4, clearance: 317 mL/min/kg
Compound 4: the middle estimate sits 1.6-fold (0.20 log units) below what was measured; the range from low to high includes it.
By their numbers in this assay, from the lowest: compound 1; then compounds 3, 2 and 4 (each within the scatter of the next).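

In this assay, the step of a 1.3-fold higher number from compound 3 to compound 4 (0.10 log units; within the scatter) shows that, on the sulfonyl sulfur, 2,6-dimethylmorpholin-4-yl can replace 2-(hydroxymethyl)pyrrolidin-1-yl without a shift beyond the scatter. The hydrogen-bond donor leaves and the five-membered ring gives way to a six-membered one, yet clearance stays within the scatter. No measurement available here bears on this result.

Open, as far as these compounds go, is whether piperazin-1-yl on the sulfonyl sulfur, or a carboxylic acid in place of the hydroxymethyl, would lower clearance on the shared core. Compound 1 differs from compound 3 in more than one place, so its lower number cannot be traced to one group.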